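This account rests on a few compounds, and the source may have more. Where it says the series, first, only, none or still open, it means among the compounds named here.

Measured in a functional assay with Rattus norvegicus as the target; a lower number here means that less compound is needed, a higher number that more compound is needed for the effect:
- compound 1 `CNS(=O)(=O)c1ccc2c(c1)C(n1ccccc1=O)=CC(C)(C)O2`: 138 nM
- compound 2 `CC1(C)C=C(n2ccccc2=O)c2cc(S(=O)(=O)NCCO)ccc2O1`: 1000 nM

Compound 1 holds the lower of the two numbers in this assay, so less of it is needed for the effect. Going by the values given here, the only measured step is a 7.2-fold higher number from compound 1 to compound 2 (0.86 log units; beyond the scatter). This modest change, beyond the scatter, places hydroxymethyl in place of hydrogen on a saturated chain carbon bound to a sulfonamide nitrogen.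

Compound 3 `CC1(C)C=C(n2ccccc2=O)c2cc(S(=O)(=O)Nc3ccccc3)ccc2O1` keeps the core of compound 1 but carries phenyl in place of methyl on a sulfonamide nitrogen. The measured step bears on this change only loosely. Among the compounds with values here, it too alters the group on the sulfonamide nitrogen, but no measured compound has a ring there. With that single guide, a 7.2-fold higher number from compound 1 to compound 2 (0.86 log units; beyond the scatter), a rise in the number is expected in this assay, probably smaller than that step, and the direction remains uncertain. The expected change is a 2.5-fold higher number from compound 1 to compound 3 (0.40 log units; beyond the scatter). Compound 3 is estimated at 350 nM, with an expected range from 70 nM to 1700 nM.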

Compound 3, half-maximal effective concentration: 13.2 nM
For compound 3 the middle estimate is 27-fold (1.42 log units) above the measured one, and the stated range ends above it.
By their numbers in this assay, from the lowest: compound 3; then compound 1; then compound 2.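

In this assay a ring on the sulfonamide nitrogen does not raise the number: phenyl in place of methyl gives a 10-fold lower number from compound 1 to compound 3 (1.02 log units; beyond the scatter) and so runs opposite to the rise seen with the 2-hydroxyethyl group, which means that changes on this nitrogen do not all move the number the same way. Phenyl in place of 2-hydroxyethyl gives a 76-fold lower number from compound 2 to compound 3 (1.88 log units; beyond the scatter) and this is the widest gap among the three compounds, whose numbers now spread far on the strength of the group at this one place, with compound 3 lowest and both of its steps beyond the scatter. Nothing available here accounts for the effect of the phenyl group.

The compounds shown leave open whether the lower number belongs to the phenyl ring itself or would also come with a benzyl group, a pyridine ring or a chlorophenyl group on the same nitrogen. They also do not tell whether a longer alkyl chain would follow phenyl or 2-hydroxyethyl, or what a second methyl group on this nitrogen would do.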